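Swapping a Furan for a Pyrrole on a Shared Core

The source may hold more compounds than are shown below. What is called first, only, known or untested is meant among the compounds shown, and "the series" means these compounds.

Measured so far in an ADME assay on HEL cells (Homo sapiens) for cytotoxicity, with a stated time of 3 days; a higher number here means that more compound is tolerated, a lower number that less compound is tolerated:
- compound 1, `C=Cc1ccc(-c2cc(C)c3ncc(CSCc4ccccc4)n3c2)cc1`: >= 100 ug/mL
- compound 2, `Cc1cc(-c2ccoc2)cn2c(CSCCc3ccccc3)cnc12`: > 4 ug/mL

Two compounds share the same fused core and carry a benzyl- or phenethyl-bearing thioether chain, and differ in the aromatic ring attached to the core. For compound 1 the value is a limit of this assay, >= 100 ug/mL, not a number. For compound 2 the value is also a limit of this assay, > 4 ug/mL. Going by the values given here, compound 2 thus stands only at a lower bound, and the one other value shown is itself a limit (the limit of >= 100 ug/mL in this assay, at which 1 of the 2 values shown sits), so the two cannot be placed in any order; no step between them is given.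

Compound 3, `Cc1cc(-n2cccc2)cn2c(CSCCc3ccccc3)cnc12`, has not yet been measured. It differs from compound 2 in one place: 1H-pyrrol-1-yl in place of furan-3-yl on an aromatic carbon. With compound 2 sitting at a limit (the limit of > 4 ug/mL in this assay, at which 1 of the 2 values shown sits), the step from compound 2 to compound 3 is expected to be none beyond the scatter, and a step that the limit leaves unreadable from compound 2 to compound 3 is the estimated change. Compound 3 is therefore expected to give about 20 ug/mL, in a range from 4 ug/mL to 100 ug/mL.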

Compound 3, minimum cytotoxic concentration: >= 4 ug/mL
Compound 3: a limit, no number; the forecaster's own chance of this, stated with the estimate: 60%; the middle value does not contradict the limit.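

In this assay, compound 2 and compound 3 each stand only at a limit of the assay, not at a number, so no step can be read for 1H-pyrrol-1-yl in place of furan-3-yl. The compounds shown leave open whether this swap changes the amount of compound tolerated at all, and in which direction.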